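This account rests on a few compounds, and the source may have more. Where it says the series, first, only, none or still open, it means among the compounds named here.

Measured so far:
- compound 1 `Oc1cccc2[nH]c(Cc3ccc(Oc4ccccc4)cc3)nc12`: 5500 nM
- compound 2 `CCS(=O)(=O)Nc1ccc2[nH]c(Cc3ccc(Oc4ccccc4)cc3)nc2c1`: 2800 nM
- compound 3 `Oc1ccc2[nH]c(CN3CCC(Cc4ccccc4F)CC3)nc2c1`: 730 nM

In an assay on membranes from brain for binding affinity to Adrenergic receptor alpha-1 (Rattus norvegicus) (a higher number here means a weaker inhibitor, a lower number a stronger inhibitor), compound 3 stands lowest of the three numbers; compound 2 is nearest to it and compound 1 furthest, and both gaps lie beyond the scatter. Compound 4 `Oc1ccc2[nH]c(CN3CCC(Cc4cccc(F)c4)CC3)nc2c1` keeps every atom of compound 3 and changes only one thing: 3-fluorophenyl in place of 2-fluorophenyl on a saturated chain carbon bound to a saturated ring carbon. Going by the values given here, no measured pair shows this kind of change, so the size of the step rests on no precedent. A small shift in either direction is expected, most likely none beyond the scatter, as the step of a 1.1-fold higher number from compound 3 to compound 4 (0.04 log units; within the scatter) is meant to express. Compound 4 is therefore estimated at 800 nM, within a range from 300 nM to 2200 nM.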

Compound 4, half-maximal inhibitory concentration: 520 nM
Estimate against measurement, compound 4: 1.5-fold (0.19 log units) above; the measured number falls inside the stated range.
By their numbers in this assay, from the lowest: compounds 4 and 3 (each within the scatter of the next); then compounds 2 and 1 (each within the scatter of the next).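

In this assay, going by these compounds alone, compounds 3 and 4 form the first pair that differs in one place, and 3-fluorophenyl in place of 2-fluorophenyl on a saturated chain carbon bound to a saturated ring carbon gives a 1.4-fold lower number from compound 3 to compound 4 (0.15 log units; within the scatter). Where the fluorine stands on this phenyl ring therefore makes no difference this assay can resolve. Nothing available offers an explanation for this result.

The compounds shown leave open whether an unsubstituted phenyl, a pyridine or a carboxylic acid at this place would move the number beyond the scatter.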